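Cytotoxicity series: three analogues at the limit, compound 4 pending

This account rests on a few compounds, and the source may have more. Where it says the series, first, only, none or still open, it means among the compounds named here.

Compound 1 `O=c1ccoc2cc(OCc3cn(Cc4cccc(Br)c4)nn3)ccc12` gives > 100000 nM in a functional assay on MDA-MB-231 cells (Homo sapiens) for cytotoxicity, read by MTT assay, with a stated time of 48 h (a lower number here means a stronger inhibitor, a higher number a weaker inhibitor), a limit of the assay rather than a number.
Compound 2 `O=c1ccoc2cc(OCc3cn(Cc4ccc(F)cc4)nn3)ccc12` gives > 100000 nM in this assay, again a limit.
Compound 3 `O=c1ccoc2cc(OCc3cn(Cc4cccc(Cl)c4)nn3)ccc12` gives > 100000 nM in this assay, also a limit.

Compound 1 therefore stands at the limit, as do the other two: the limit of > 100000 nM in this assay, at which 3 of the 3 values shown sit. The steps a step that the two limits leave unreadable from compound 1 to compound 2, a step that the two limits leave unreadable from compound 1 to compound 3 and a step that the two limits leave unreadable from compound 2 to compound 3 show only that no variation of the phenyl substituent moved any value into the readable range. The change to compound 4 `O=c1ccoc2cc(OCc3cn(Cc4cccc([N+](=O)[O-])c4)nn3)ccc12` is nitro in place of bromo on an aromatic carbon. Among the compounds with values here, no measured step speaks for or against this exchange, so no shift beyond the scatter is expected, and the value is expected to remain at the limit. Compound 4 is estimated at 150000 nM (40000 nM to 600000 nM), with the expected step being a step that the limit leaves unreadable from compound 1 to compound 4.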

Compound 4, half-maximal inhibitory concentration: > 100000 nM
Compound 4 ended at the assay's limit; the forecaster's own chance of this, stated with the estimate: 80%; the middle value does not contradict the limit.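

Compound 4 joins compound 1, compound 2 and compound 3 at the limit, so none of its steps to them can be read: the limit of > 100000 nM in this assay, at which 4 of the 4 values shown sit.

The compounds shown leave open which change to the phenyl substituent or the shared core, if any, would bring a value into the readable range.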